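The source may hold more compounds than are shown below. What is called first, only, known or untested is meant among the compounds shown, and "the series" means these compounds.

Of the compounds shown here, two carry a number so far. Compound 1 `Nc1ccccc1NC(=O)c1ccc(Cn2cnc3c(Nc4ccccc4)nc(Cl)nc32)cc1` gives 49.6% in a functional assay on HepG2 cells (Homo sapiens) for antiproliferative activity, read by CCK-8 assay, with a stated time of 72 h, tested at 2 uM (on this read-out lower numbers stand for a weaker effect and higher numbers for a stronger effect at the one concentration tested), while compound 2 `Nc1ccccc1NC(=O)/C=C/c1ccc(Cn2cnc3c(NC4CCCCC4)nc(Cl)nc32)cc1` gives 3.83% in the same assay. Compound 2 thus stands lowest of the two values, with compound 1 the nearest and its number lying beyond the usual scatter above it.

The next compound, compound 3 `Nc1ccccc1NC(=O)/C=C/c1ccc(Cn2cnc3c(Nc4ccccc4)nc(Cl)nc32)cc1`, has not been measured. It differs from compound 2 in one place: phenyl in place of cyclohexyl on a nitrogen on an aromatic ring. Going by the values given here, the two measured compounds share no single-point step, so no counted step is available for this change. Among the compounds with values here, the anilino group that enters is also present in compound 1, whose value of 49.6% is the higher of the two known numbers, and the cyclohexylamino group that leaves belongs to the lower-reading compound 2.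

On this basis the step from compound 2 to compound 3 is expected to be upward and larger than the scatter, about a number 26.2 percentage points higher from compound 2 to compound 3 (beyond the scatter). Compound 3 is accordingly estimated at 30%, with a range from 5% to 60%.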

Compound 3, a percentage reported as inhibition, at one concentration (the size of the read-out at that concentration, not a potency): 16.4%
For compound 3 the middle estimate is 13.6 percentage points above the measured one; the measured number falls inside the stated range.
By their numbers in this assay, from the lowest: compound 2; then compound 3; then compound 1.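

In this assay the change on this nitrogen now has a direction: phenyl in place of cyclohexyl gives a number 12.6 percentage points higher from compound 2 to compound 3 (beyond the scatter), and the two groups match in heavy atoms while differing in that one ring is aromatic and the other is not. With the anilino group held constant, the other change, 2-((2-aminophenyl)carbamoyl)ethenyl in place of (2-aminophenyl)carbamoyl on an aromatic carbon, gives a number 33.2 percentage points lower from compound 1 to compound 3 (beyond the scatter), which is the larger of the two steps and is read in the opposite direction. No supporting data accompany these results to explain either step.

As far as these compounds go, whether the order of anilino and cyclohexylamino holds when the (2-aminophenyl)carbamoyl group stands in place of the longer ethenyl chain remains open, as the two amino groups are compared here only on the longer chain. Also open, from the compounds shown here alone, is how an open-chain alkylamino group, such as butylamino, or an anilino ring carrying a methoxy group would read on this nitrogen, and whether a hydroxamic acid in place of the 2-aminophenyl amide would alter either step.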